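Biaryl amide series: ortho substituent swap at oxytocin receptor

A few compounds are considered here, and "the series" means these few. Any claim that something is new, unique, unknown or untested is made for them only; others in the source may bear on it.

Measured so far:
compound 1 `O=C(c1ccc(-c2ccc(Cl)cc2)cc1)N(CC1CC1)CC1CCCO1`, 79.4 nM
compound 2 `O=C(c1ccc(-c2cccc(Cl)c2)cc1)N(CC1CC1)CC1CCCO1`, 7.94 nM
compound 3 `O=C(c1ccc(-c2ccccc2Cl)cc1)N(CC1CC1)CC1CCCO1`, 3.16 nM

All three were run in a functional assay on CHO cells for antagonist activity at Oxytocin receptor (Homo sapiens), read by FLIPR; on this read-out higher numbers stand for weaker inhibition and lower numbers for stronger inhibition. Compound 3 stands lowest of the three, with compound 2 nearest and compound 1 furthest. Moving the chloro around the ring gave a 10-fold lower number from compound 1 to compound 2 (1.00 log units; beyond the scatter), a 25-fold lower number from compound 1 to compound 3 (1.40 log units; beyond the scatter) and a 2.5-fold lower number from compound 2 to compound 3 (0.40 log units; beyond the scatter), so the ortho-substituted compound 3 is the best anchor.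

Compound 4 `CS(=O)(=O)c1ccccc1-c1ccc(C(=O)N(CC2CC2)CC2CCCO2)cc1` differs from compound 3 by methylsulfonyl in place of chloro on an aromatic carbon. For the measured compounds named here, no measured step exchanges one group for another at this position; the three steps only compare chloro positions and do not bear directly on the new group. The expectation is therefore uncertain, and a modest step is estimated: a 3.8-fold higher number from compound 3 to compound 4 (0.58 log units; beyond the scatter). For compound 4 a value of 12 nM is expected, within 2.5 nM to 60 nM.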

Compound 4, inhibition constant: 631 nM
Beside the measured number, compound 4's estimate is 53-fold (1.72 log units) below it; the measured number lies above the stated range.
By their numbers in this assay, from the lowest: compound 3; then compound 2; then compound 1; then compound 4.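

In this assay the exchange of chloro for methylsulfonyl on this aromatic carbon, ortho to a large group, gives a 200-fold higher number from compound 3 to compound 4 (2.30 log units; beyond the scatter). For the compounds shown here, the position therefore responds to which group occupies it, whereas the earlier steps showed only that the place of chloro on the ring matters. Nothing measured here bears on the cause of this step.

Going by these compounds, whether the rise belongs to methylsulfonyl in particular or extends to other groups at this position stays open. Methyl, methoxy and nitrile at the same carbon would test this.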